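This account rests on a few compounds, and the source may have more. Where it says the series, first, only, none or still open, it means among the compounds named here.

Measured compounds:
- Compound 1, `Cc1cc(Cl)cc(Cl)c1S(=O)(=O)N1CCC(N2CCC(C)CC2)CC1`: 0.45 nM
- Compound 2, `CC1CCN(C2CCN(S(=O)(=O)c3ccccc3Br)CC2)CC1`: 3 nM
- Compound 3, `C#CCCC(=O)CC1CCN(C2CCN(S(=O)(=O)c3c(C)cc(C)cc3C)CC2)CC1`: 2.1 nM

In a functional assay on HT-29 cells (Homo sapiens) for antiproliferative activity, read by CellTiter-Glo, with a stated time of 72 h (a higher number here means a weaker inhibitor, a lower number a stronger inhibitor), compound 2 gives 3 nM, the highest of the three numbers. Its nearest neighbour is compound 3, which gives 2.1 nM, a gap that lies within the scatter, so no order between these two can be claimed. Compound 1, which gives 0.45 nM, lies beyond the scatter from compound 2 and is the stronger inhibitor of that pair.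

Compound 4, `CC1CCN(C2CCN(S(=O)(=O)c3ccccc3-c3ccccc3)CC2)CC1`, has not yet been measured in this assay. It differs from compound 2 in one place: phenyl in place of bromo on an aromatic carbon. Going by the values given here, no step between measured compounds covers this change, so the expected direction rests on the three numbers alone: compounds 1 and 3 show that the shared core tolerates varied substitution on the aromatic ring, but none of them carries a second aromatic ring there.

Compound 4 is estimated to give 6 nM, with a plausible range from 1.5 nM to 30 nM. The step this estimate means, a 2.0-fold higher number from compound 2 to compound 4 (0.30 log units; within the scatter), is expected to be modest, toward a weaker inhibitor, and possibly within the scatter.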

Compound 4, half-maximal inhibitory concentration: 0.74 nM
Compound 4: middle estimate off by 8.1-fold (0.91 log units), on the high side; measured number below the stated range.
By their numbers in this assay, from the lowest: compounds 1 and 4 (each within the scatter of the next); then compounds 3 and 2 (each within the scatter of the next).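

In this assay the exchange of bromo for phenyl on an aromatic carbon, ortho to a large group, gives a 4.1-fold lower number from compound 2 to compound 4 (0.61 log units; beyond the scatter) and so a stronger inhibitor. The earlier compounds shown here carried only small groups on the aromatic ring, whereas this result shows that the position accepts a whole second aromatic ring in place of a single bromine atom, without any loss in this read-out. No evidence at hand bears on what lies behind this step.

The compounds shown do not tell whether a pyridine ring, a cyclohexyl group or a phenyl carrying an amine or a carboxylic acid would give a similar number at this position. They also leave open whether phenyl would give a similar step on the core of compound 3, with its longer chain.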